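A few compounds are considered here, and "the series" means these few. Any claim that something is new, unique, unknown or untested is made for them only; others in the source may bear on it.

Working notes on the series in a toxicity assay on Huh-7.5 cells (Homo sapiens) for inhibition, read by MTT assay, with a stated time of 96 h; a higher number here means that more compound is tolerated, a lower number that less compound is tolerated. Compound 1 `CCC(=O)Nc1cc(C(=O)Nc2ccc(N(C)C)cc2)ccc1OC(C)C` gives 80600 nM, compound 2 `CCC(=O)Nc1cc(C(=O)Nc2ccc(OC)cc2)ccc1OC(C)C` gives 113000 nM, and compound 3 `CCC(=O)Nc1cc(C(=O)Nc2ccc(OC)cc2)ccc1OC` gives 109000 nM; compound 3 thus stands second highest of the three, with all three numbers within the scatter of one another. Compound 4 `CCC(=O)Nc1cc(C(=O)Nc2ccc(N(C)C)cc2)ccc1OC` differs from compound 3 by dimethylamino in place of methoxy on an aromatic carbon. The step that bears on it is the same exchange run the other way, a 1.4-fold higher number from compound 1 to compound 2 (0.15 log units; within the scatter), while a 1.0-fold lower number from compound 2 to compound 3 (0.02 log units; within the scatter) shows the isopropyl-to-methyl exchange is also flat. On that basis no step beyond the scatter is expected from compound 3 to compound 4, with at most a slight downward lean because a 1.4-fold higher number from compound 1 to compound 2 (0.15 log units; within the scatter) leaned upward. Compound 4 is therefore estimated at 85000 nM, range 45000 nM to 160000 nM, a step of a 1.3-fold lower number from compound 3 to compound 4 (0.11 log units; within the scatter).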

Compound 4, half-maximal cytotoxic concentration: 171000 nM
Beside the measured number, compound 4's estimate is 2.0-fold (0.30 log units) below it; measured number above the stated range.
By their numbers in this assay, from the lowest: compounds 1, 3, 2 and 4 (each within the scatter of the next, the first and the last beyond it).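

In this assay, dimethylamino in place of methoxy on this aromatic carbon gives a 1.6-fold higher number from compound 3 to compound 4 (0.20 log units; within the scatter), so this exchange shows no settled direction across the two cores: the same change on two cores in this assay, a 1.4-fold higher number (0.15 log units; within the scatter) from compound 1 to compound 2 and a 1.6-fold lower number (0.20 log units; within the scatter) from compound 4 to compound 3, 2.2-fold (0.34 log units) apart, within the scatter of two such steps. Methyl in place of isopropyl on the oxygen, flat on the methoxy core, gives a 2.1-fold higher number from compound 1 to compound 4 (0.33 log units; beyond the scatter) on the dimethylamino core, the only listed step beyond the scatter, yet the two steps do not separate: the same change on two cores in this assay, a 1.0-fold lower number (0.02 log units; within the scatter) from compound 2 to compound 3 and a 2.1-fold higher number (0.33 log units; beyond the scatter) from compound 1 to compound 4, 2.2-fold (0.34 log units) apart, within the scatter of two such steps. Going by these compounds, whether a carboxylic acid or a primary amine on this aromatic carbon, or a longer chain on the oxygen, would give a step beyond the scatter stays open.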